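This account rests on a few compounds, and the source may have more. Where it says the series, first, only, none or still open, it means among the compounds named here.

Working notes on the series, read in a functional assay on A-375 cells (Homo sapiens) for inhibition, read by CCK-8 assay, with a stated time of 72 h; on this read-out higher numbers stand for weaker inhibition and lower numbers for stronger inhibition. For the measured compounds named here, compound 1 (`O=C(NO)c1ccc(CNC(=O)c2n[nH]cc2NC(=O)c2c(Cl)cccc2Cl)cc1`) gives 5050 nM, the higher of the two numbers so far. Compound 2 (`Nc1ccccc1NC(=O)c1ccc(CNC(=O)c2n[nH]cc2NC(=O)c2c(Cl)cccc2Cl)cc1`) gives 1200 nM. Going by the values given here, the only measured step is a 4.2-fold lower number from compound 1 to compound 2 (0.62 log units; beyond the scatter), a modest one. That step puts 2-aminophenyl in place of hydroxy on an amide-type nitrogen, while the 2,6-dichlorophenyl on the carbonyl carbon stays the same in both compounds.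

Compound 3 (`O=C(NO)c1ccc(CNC(=O)c2n[nH]cc2NC(=O)c2ccccc2F)cc1`) keeps the hydroxy of compound 1 and differs at another place: 2-fluorophenyl in place of 2,6-dichlorophenyl on a carbonyl carbon. Among the compounds with values here, the measured step therefore bears on this change only indirectly, and no measured pair varies the group on the carbonyl carbon. As far as these compounds go, with nothing measured at that place, no step beyond the scatter is expected in this assay, although a shift in either direction remains open, with a slight lean toward a higher number. The expected step is a 1.2-fold higher number from compound 1 to compound 3 (0.07 log units; within the scatter). Compound 3 is estimated at 6000 nM, with an expected range of 2000 nM to 18000 nM.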

Compound 3, half-maximal inhibitory concentration: 3010 nM
Beside the measured number, compound 3's estimate is 2.0-fold (0.30 log units) above it; low and high end bracket the measured number.
By their numbers in this assay, from the lowest: compound 2; then compounds 3 and 1 (each within the scatter of the next).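

In this assay, the first change read at this place, 2-fluorophenyl in place of 2,6-dichlorophenyl on a carbonyl carbon, gives a 1.7-fold lower number from compound 1 to compound 3 (0.22 log units; within the scatter). With hydroxy on the amide-type nitrogen, the swap from two chlorine atoms to a single fluorine atom therefore leaves the read-out without a step beyond the scatter, and neither group can be ranked over the other at this place. No supporting evidence on hand speaks to why the two groups read alike.

Open is whether the same holds with 2-aminophenyl in place of hydroxy, where the 2-fluorophenyl group has no reading among the compounds shown, so the two changes cannot yet be judged together. For the compounds shown here, also open is how far this place accepts groups further from these two, such as an unsubstituted phenyl, a 2-methoxyphenyl or a saturated cyclohexyl ring, since the present pair covers only two halogen-bearing phenyl rings and says nothing about the wider range of groups on the carbonyl carbon.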